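Trifluoromethyl for Methoxy on the Aryl Ring of Compound 1

A few compounds are considered here, and "the series" means these few. Any claim that something is new, unique, unknown or untested is made for them only; others in the source may bear on it.

Three measured compounds share one core. Compound 1 `COc1cccc(N2CCN(C(=O)C(C)N3C(=O)CCC3=O)CC2)c1` carries a methoxyphenyl group, and in a functional assay on the whole organism (strain Swiss) with Mus musculus as the target, in the maximal electroshock model, with a stated time of 2 h, at a dose of 300 mg/kg by the intraperitoneal route (on this read-out lower numbers stand for a weaker effect and higher numbers for a stronger effect at the one dose given), compound 1 gives 0%. Compound 3 `CCC(C(=O)N1CCN(c2cccc(OC)c2)CC1)N1C(=O)CCC1=O` gives 0%, and no change at the digits printed from compound 1 to compound 3 (within the scatter). Compound 2 `CC(C(=O)N1CCN(c2ccccc2F)CC1)N1C(=O)CCC1=O` gives 25%, and a number 25 percentage points higher from compound 1 to compound 2 (beyond the scatter). Compound 1 therefore stands level with compound 3 at the digits given, the two together the lowest of the three numbers, with compound 2 the furthest away.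

Compound 4 `CC(C(=O)N1CCN(c2cccc(C(F)(F)F)c2)CC1)N1C(=O)CCC1=O` awaits measurement. Against compound 1 the change is trifluoromethyl in place of methoxy on an aromatic carbon, on an aromatic carbon meta to a large group. Among the measured compounds shown here, of the measured steps, the one from compound 1 to compound 2 also alters the group on the aromatic ring and bears most on this case, its size being a number 25 percentage points higher from compound 1 to compound 2 (beyond the scatter). The step from compound 1 to compound 3 alters the chain instead and moved nothing, so it offers little guidance here. For the measured compounds named here, no measured pair swaps methoxy for trifluoromethyl, so the direction rests on a single ring change. A modest rise is expected, and for compound 4 the step expected is a number 25 percentage points higher from compound 1 to compound 4 (beyond the scatter). Compound 4 is thus estimated to give 25%, within a range from 0% to 50%.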

Compound 4, a percentage reported as activity, at one dose (the size of the read-out at that dose, not a potency): 100%
Compound 4: the middle estimate sits 75 percentage points below what was measured; the whole stated range lies below it.
By their numbers in this assay, from the lowest: compounds 1 and 3 (each within the scatter of the next); then compound 2; then compound 4.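

In this assay, the aromatic carbon carrying the methoxy group of compound 1 proves far more responsive than the earlier ring change suggested: trifluoromethyl in place of methoxy gives a number 100 percentage points higher from compound 1 to compound 4 (beyond the scatter), a large step where a number 25 percentage points higher from compound 1 to compound 2 (beyond the scatter) was modest. Set against no change at the digits printed from compound 1 to compound 3 (within the scatter), this places the clear movement among these compounds on the aryl ring rather than on the chain, although the chain change has been seen only with the methoxy group in place. The swap takes away methoxy, with its 2 heavy atoms and 1 hydrogen-bond acceptor, and brings in trifluoromethyl, with 4 heavy atoms and 0 hydrogen-bond acceptors, but no measurement here bears on why this change has so large an effect.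

The compounds shown leave open whether chlorine, a nitrile or a hydroxyl group on the same aromatic carbon would have a comparable effect. They also leave open whether the extra methyl group on the chain of compound 3 would still make no difference with trifluoromethyl on the ring.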